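Working notes: one stereocentre changed from compound 2

The source may report more compounds than this note shows. Statements on the series, on what has been measured and on what is new or still open speak of the compounds shown alone.

Compound 1 `Cc1cn([C@H]2C[C@H](CC3=CC(=O)C(=O)C=C3)[C@@H](CO[Si](C)(C)C(C)(C)C)O2)c(=O)[nH]c1=O`: no result reported
Compound 2 `COc1ccc(C2([C@H]3C[C@H](n4cc(C)c(=O)[nH]c4=O)O[C@@H]3CO[Si](C)(C)C(C)(C)C)SCCCS2)cc1OC`: 3240 nM

Among the measured compounds shown here, in a functional assay on LOX IMVI cells (Homo sapiens) for inhibition, read by sulforhodamine B assay, with a stated time of 48 h (on this read-out lower numbers stand for stronger inhibition of growth and higher numbers for weaker inhibition of growth), compound 2 gives 3240 nM, the only number so far. For the measured compounds named here, compound 1 has an entry without a number, so compound 2 cannot yet be ranked and no measured step is available.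

Compound 3 `COc1ccc(C2([C@H]3C[C@@H](n4cc(C)c(=O)[nH]c4=O)O[C@@H]3CO[Si](C)(C)C(C)(C)C)SCCCS2)cc1OC` is still to be measured. Its change from compound 2 is the two compounds have the same atoms and bonds and differ only in configuration as drawn: 1 of 3 stereo elements differ; a stereocentre at a saturated ring carbon is drawn R in compound 2 and S in compound 3: the same atoms and bonds, with a stereocentre at a saturated ring carbon drawn R in compound 2 and S in compound 3.

Going by the values given here, no measured pair shows what such a change does here. The step of a 1.0-fold lower number from compound 2 to compound 3 (0.01 log units; within the scatter) is therefore expected to stay within the usual scatter in this assay, with no direction favoured. This expectation rests on compound 2 alone, at 3240 nM.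

For compound 3 the estimated value is 3200 nM, with an expected range from 1100 nM to 9500 nM.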

Compound 3, concentration for 50% growth inhibition: 8130 nM
Beside the measured number, compound 3's estimate is 2.5-fold (0.40 log units) below it; measured number inside the range.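

In this assay, inverting one stereocentre at a saturated ring carbon, from R to S as drawn, gives a 2.5-fold higher number from compound 2 to compound 3 (0.40 log units; beyond the scatter). Among the compounds shown here, this is the first measured step, and it shows that the configuration at this carbon matters for growth inhibition on its own, with the R drawing carrying the lower number of the pair. The modest step can be assigned to configuration alone: the fact that compounds 2 and 3 differ only in the configuration as drawn

On these data alone, whether the step keeps its direction and size with a free hydroxyl group or an amine in place of the silyl ether remains open. The compounds shown vary only this one stereocentre, so the effect of the other two stereocentres on the read-out also remains open.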